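This account rests on a few compounds, and the source may have more. Where it says the series, first, only, none or still open, it means among the compounds named here.

Measured so far in a toxicity assay on Vero cells (Chlorocebus sabaeus) for inhibition, read by MTT assay, with a stated time of 48 h; a lower number here means a stronger inhibitor, a higher number a weaker inhibitor:
Compound 1 `O=C(N/N=C/c1c(-c2cc3ccccc3oc2=O)[nH]c2ccccc12)c1ccccc1` gives 121000 nM.
Compound 2 `O=C(N/N=C/c1c(-c2cc3ccc(Br)cc3oc2=O)[nH]c2ccccc12)c1ccccc1` gives > 200000 nM, which is a limit of the assay and not a number.

Compound 2 thus stands at the limit in this assay, with no number of its own beyond that (the limit of > 200000 nM in this assay, at which 1 of the 2 values shown sits). Among the measured compounds shown here, the one measured step, an at least 1.6-fold higher number from compound 1 to compound 2 (0.21 log units; that floor lies within the scatter), rests on the floor set by that limit, and that floor lies within the scatter, so it shows no change that can be called real.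

Compound 3 `O=C(N/N=C/c1c(-c2cc3ccc(Br)cc3oc2=O)[nH]c2ccccc12)c1cccc(Br)c1` differs from compound 2 by bromo in place of hydrogen on an aromatic carbon. The step from compound 1 to compound 2 is the only one that bears on it, being likewise bromo in place of hydrogen on an aromatic carbon, and its size is at most a floor within the scatter with no sign of a stronger inhibitor. The step that the limit leaves unreadable from compound 2 to compound 3 is therefore expected to be small, none beyond the scatter, and compound 3 is expected to sit at the limit again. Compound 3 is estimated at 260000 nM, between 110000 nM and 650000 nM.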

Compound 3, half-maximal inhibitory concentration: > 200000 nM
Compound 3: no number, only a limit (the forecaster's own chance of this, stated with the estimate: 75%); the middle value lies beyond the limit too.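

In this assay compound 3 gives > 200000 nM, which is a limit of the assay and not a number. No step can be read between compound 2 and compound 3, because both stop at the same limit: the limit of > 200000 nM in this assay, at which 2 of the 3 values shown sit. As far as these compounds go, whether bromo in place of hydrogen on the benzoyl ring changes the number at all remains open.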